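Swapping Fluoro for Dimethylamino on a Shared Core

The compounds below may be only part of what the source reports. "The series", "measured", "known", "first", "only" and "open" are said of these compounds alone.

Of the compounds shown here, three built on one shared core have been tested in a functional assay on HepG2 cells (Homo sapiens) for cytotoxicity, read by MTT assay, with a stated time of 72 h; on this read-out higher numbers stand for weaker inhibition and lower numbers for stronger inhibition. Compound 1 `O=C1C=CCC/C1=C\C=C\c1ccc(F)cc1` gives 2900 nM in this assay. Compound 2 `O=C1C=CCC/C1=C\C=C\c1ccccc1[N+](=O)[O-]` gives 6800 nM, and compound 3 `COc1cc(/C=C/C=C2\CCC=CC2=O)ccc1O` gives 900 nM. Among these three numbers compound 1 stands second highest: compound 2 sits above it beyond the scatter, and compound 3 sits below it, also beyond the scatter. Compound 4 `CN(C)c1ccc(/C=C/C=C2\CCC=CC2=O)cc1` has not yet been measured. It differs from compound 1 in one place: dimethylamino in place of fluoro on an aromatic carbon. For the measured compounds named here, no measured pair shows this exact change, so the step can only be guessed; a modest lowering of the number is expected, a 1.9-fold lower number from compound 1 to compound 4 (0.29 log units; within the scatter). Compound 4 is therefore expected to give about 1500 nM, within a range from 500 nM to 5000 nM.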

Compound 4, half-maximal inhibitory concentration: 1100 nM
Estimate against measurement, compound 4: 1.4-fold (0.13 log units) above, and the stated range covers the measured number.
By their numbers in this assay, from the lowest: compounds 3 and 4 (each within the scatter of the next); then compound 1; then compound 2.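

For the compounds shown here, at the aromatic carbon that carries fluoro in compound 1, this is the first one-place change on the shared core. In this assay dimethylamino in place of fluoro gives a 2.6-fold lower number from compound 1 to compound 4 (0.42 log units; beyond the scatter) and so a modest gain, showing that three heavy atoms can replace one here without weakening inhibition. Nothing measured here accounts for this step. Going by these compounds, whether a plain amino group or chloro at this same place would shift the number in the same direction stays open. So does whether the same swap would have a similar effect on a different core.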